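The source may hold more compounds than are shown below. What is called first, only, known or untested is meant among the compounds shown, and "the series" means these compounds.

In a functional assay on MCF7 cells (Homo sapiens) for antiproliferative activity, read by MTT assay, with a stated time of 48 h (on this read-out lower numbers stand for stronger inhibition and higher numbers for weaker inhibition), the values so far are these:
compound 1 (`CC(=O)N1N=C(c2ccc3ccccc3c2)OC1c1ccc(F)cc1`) gives 3.02 ug/mL
compound 2 (`CC(=O)N1N=C(c2ccc3ccccc3c2)OC1c1ccccc1[N+](=O)[O-]`) gives 18.2 ug/mL

Compound 2 holds the higher of the two numbers, which makes it the weaker of the pair. Compound 3 (`CC(=O)N1N=C(c2ccc3ccccc3c2)OC1c1ccccc1O`) follows from compound 2 by one change (hydroxy in place of nitro on an aromatic carbon) that puts hydroxy in place of nitro on an aromatic carbon. For the measured compounds named here, the only measured step is a 6.0-fold higher number from compound 1 to compound 2 (0.78 log units; beyond the scatter) and it brings in 2-nitrophenyl in place of 4-fluorophenyl. Going by the values given here, no measured compound carries the hydroxy, so that step guides the size only and says little about direction. A move toward a lower number in this assay is expected, held weakly, since compound 2 is the higher of just two values. The expected change is a 2.3-fold lower number from compound 2 to compound 3 (0.36 log units; beyond the scatter) and it should stay smaller than the measured step. Compound 3 is estimated at 8 ug/mL with an expected range from 2.5 ug/mL to 25 ug/mL in this read-out.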

Compound 3, half-maximal inhibitory concentration: 2.12 ug/mL
Beside the measured number, compound 3's estimate is 3.8-fold (0.58 log units) above it; measured number outside the range, below it.
By their numbers in this assay, from the lowest: compounds 3 and 1 (each within the scatter of the next); then compound 2.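

Within this assay, this aromatic carbon, ortho to a large group, proves sensitive to the substituent it carries: hydroxy in place of nitro gives an 8.6-fold lower number from compound 2 to compound 3 (0.93 log units; beyond the scatter). The 2-hydroxyphenyl and 4-fluorophenyl compounds cannot be told apart, with a 1.4-fold lower number from compound 1 to compound 3 (0.15 log units; within the scatter), so a group at this place does not by itself bring the higher number, and among the three compounds only the 2-nitrophenyl one stands apart. Nothing available explains the size of this step.

As far as these compounds go, whether the higher number is particular to nitro stays open; an amine, a methoxy group or a carboxylic acid on the same aromatic carbon would bear on that. Also open, from the compounds shown here alone, is whether hydroxy would give a similar number on another carbon of this ring.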